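The source may report more compounds than this note shows. Statements on the series, on what has been measured and on what is new or still open speak of the compounds shown alone.

Measured so far in an ADME assay on Vero cells (Chlorocebus sabaeus) for cytotoxicity (a higher number here means that more compound is tolerated, a lower number that less compound is tolerated), are these compounds:
- compound 1 (`CO/N=C1/C(=O)N(Cc2cn(CC(=O)N3CCN(c4cc5c(cc4F)c(=O)c(C(=O)O)cn5C4CC4)CC3)nn2)c2c(F)cccc21`) gives 32 ug/mL
- compound 2 (`CO/N=C1/C(=O)N(Cc2cn(CC(=O)N3CCN(c4cc5c(cc4F)c(=O)c(C(=O)O)cn5C4CC4)CC3)nn2)c2ccc(C)cc21`) gives 8 ug/mL
- compound 3 (`CCO/N=C1/C(=O)N(Cc2cn(CC(=O)N3CCN(c4cc5c(cc4F)c(=O)c(C(=O)O)cn5C4CC4)CC3)nn2)c2ccccc21`) gives 64 ug/mL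

Compound 3 and compound 1 lie within the usual scatter of each other, so the two cannot be ranked. Compound 2 lies beyond the scatter from compound 3, with less compound tolerated.

Going from compound 3 to compound 4 (`CO/N=C1/C(=O)N(Cc2cn(CC(=O)N3CCN(c4cc5c(cc4F)c(=O)c(C(=O)O)cn5C4CC4)CC3)nn2)c2ccccc21`) means one small edit, hydrogen in place of methyl on a saturated chain carbon bound to an oxygen on an unsaturated carbon, which turns ethoxy to methoxy. Within the data shown here, no two measured compounds differ in one place only, so this change has not been seen on its own. Compound 1 at 32 ug/mL and compound 2 at 8 ug/mL already carry the methoxy, but both differ from compound 4 elsewhere and their values are far apart, so they offer only loose guidance. In this assay no step beyond the scatter is expected, with compound 1 at 32 ug/mL as the closer guide. The estimated change is a 2.0-fold lower number from compound 3 to compound 4 (0.30 log units; within the scatter) and points towards less compound tolerated, inside the scatter. For compound 4 the estimated value is 32 ug/mL with an expected range from 12 ug/mL to 80 ug/mL in this read-out.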

Compound 4, half-maximal cytotoxic concentration: 128 ug/mL
Beside the measured number, compound 4's estimate is 4.0-fold (0.60 log units) below it; measured number outside the range, above it.
By their numbers in this assay, from the lowest: compound 2; then compounds 1, 3 and 4 (each within the scatter of the next, the first and the last beyond it).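

Among these compounds, compound 4 supplies the first steps that change one place only, and in this assay the ethoxy to methoxy change gives a 2.0-fold higher number from compound 3 to compound 4 (0.30 log units; within the scatter), so at this saturated chain carbon bound to an oxygen on an unsaturated carbon, methyl and hydrogen cannot be told apart. The two edits on aromatic carbons can be read clearly: hydrogen in place of methyl gives a 16-fold higher number from compound 2 to compound 4 (1.20 log units; beyond the scatter), and hydrogen in place of fluoro gives a 4.0-fold higher number from compound 1 to compound 4 (0.60 log units; beyond the scatter), so more compound is tolerated without either group. In these four compounds, then, the single edits on aromatic carbons separate beyond the scatter while the ethyl to methyl edit does not, though nothing available here explains why.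

Going by these compounds, it remains open whether a longer chain such as propoxy at the oxygen would also stay within the scatter of compound 4. On these data alone, each aromatic step also rests on a single pair of compounds, so it is unknown whether a chloro group or an amine on an aromatic carbon would bring a similar loss of tolerated compound.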